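The compounds below may be only part of what the source reports. "The series", "measured", "known", "first", "only" and "open" are said of these compounds alone.

The series shares one core, varied at a single aromatic carbon. Compound 1 `Cc1nn(C)c(Oc2ccc(Cl)cc2)c1/C=N/OCc1ccc(C(=O)OC(C)(C)C)cc1` carries a 4-chlorophenoxy group there, and in a functional assay on SK-OV-3 cells (Homo sapiens) for cytotoxicity (on this read-out higher numbers stand for weaker inhibition and lower numbers for stronger inhibition), compound 1 gives 0.28 ug/mL. Compound 2 `Cc1nn(C)c(-n2ccnc2)c1/C=N/OCc1ccc(C(=O)OC(C)(C)C)cc1` carries 1H-imidazol-1-yl instead, and in this assay compound 2 gives 14.1 ug/mL, standing at the high end of the three measured numbers, far from compound 1 and close to compound 3. Compound 3 `Cc1nn(C)c(-n2cccn2)c1/C=N/OCc1ccc(C(=O)OC(C)(C)C)cc1`, bearing 1H-pyrazol-1-yl, gives 9.63 ug/mL in this assay. The two measured steps away from the phenoxy group were a 50-fold higher number from compound 1 to compound 2 (1.70 log units; beyond the scatter) and a 34-fold higher number from compound 1 to compound 3 (1.54 log units; beyond the scatter), while between the two azoles the step was a 1.5-fold lower number from compound 2 to compound 3 (0.17 log units; within the scatter). Compound 4 `Cc1nn(C)c(N(C)C)c1/C=N/OCc1ccc(C(=O)OC(C)(C)C)cc1` differs from compound 2 in that (dimethylamino in place of 1H-imidazol-1-yl on an aromatic carbon). Among the compounds with values here, no measured step involves dimethylamino, so the evidence is only that both small azoles sit far from compound 1 and close to each other. Compound 4 is therefore expected to remain in the weak range, with an estimated step of a 1.4-fold lower number from compound 2 to compound 4 (0.15 log units; within the scatter) in this assay. The estimate for compound 4 is 10 ug/mL, expected to fall between 3 ug/mL and 40 ug/mL.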

Compound 4, half-maximal inhibitory concentration: 9.06 ug/mL
Beside the measured number, compound 4's estimate is 1.1-fold (0.04 log units) above it; the measured number falls inside the stated range.
By their numbers in this assay, from the lowest: compound 1; then compounds 4, 3 and 2 (each within the scatter of the next).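

In this assay, dimethylamino, which has no ring, sits with the two azoles, with a 1.6-fold lower number from compound 2 to compound 4 (0.19 log units; within the scatter) and a 1.1-fold lower number from compound 3 to compound 4 (0.03 log units; within the scatter), so an aromatic ring at this position is not required for a number in this range. The gap to the 4-chlorophenoxy group remains wide, at a 32-fold higher number from compound 1 to compound 4 (1.51 log units; beyond the scatter), and thus all three groups attached through nitrogen, whether ring or open, stand far from compound 1 and cannot be told apart from one another. Nothing available explains this grouping or the gap.

From the compounds shown here alone, what remains open is whether the low number of compound 1 belongs to its ether oxygen or to its chlorinated benzene ring. A phenoxy group without chlorine, a methoxy group or a phenylamino group at this position would begin to separate the two.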